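The compounds below may be only part of what the source reports. "The series", "measured", "known", "first", "only" and "open" are said of these compounds alone.

Working notes on the ether series. The parent is compound 1 `CCCCCCCCCCO[C@H]1C=C(COC(C)=O)C(=O)[C@@H]2O[C@@](C)(OC)[C@](C)(OC)O[C@@H]12`. For the measured compounds named here, in an assay on isolated protein for inhibition of glutathione S-transferase Mu 1 (Homo sapiens), read by spectrophotometry, with a stated time of 3 min (on this read-out lower numbers stand for stronger inhibition and higher numbers for weaker inhibition), compound 1 gives 33600 nM, and this is the only number in the set: compound 2 `CO[C@]1(C)O[C@H]2[C@H](O)C(CO)=CC(=O)[C@@H]2O[C@@]1(C)OC` gives "not determined" (no result reported) in this assay, and compound 3 `CC(=O)OCC1=C[C@H](O)[C@H](O)[C@@H](O)C1=O` gives "not determined" (no result reported) in this assay, so no step between measured compounds can be drawn and compound 1 stands alone as the single reference point.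

The next entry is compound 4 `CO[C@]1(C)O[C@H]2[C@@H](OC/C=C(\C)CCC=C(C)C)C=C(COC(C)=O)C(=O)[C@@H]2O[C@@]1(C)OC`, which differs from compound 1 in one place: 2,6-dimethylhepta-1,5-dien-1-yl in place of nonyl on a saturated chain carbon bound to an oxygen on a saturated carbon. Chain length and heavy-atom count are unchanged; two double bonds outside aromatic rings enter. Going by the values given here, with no measured step to lean on, the expectation for compound 4 is a step of about a 1.3-fold lower number from compound 1 to compound 4 (0.13 log units; within the scatter), that is, none beyond the usual scatter, with at most a slight lean toward stronger inhibition. The estimate for compound 4 in this assay is 25000 nM, with a range from 8000 nM to 80000 nM.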

Compound 4, half-maximal inhibitory concentration: 177000 nM
Compound 4: middle estimate off by 7.1-fold (0.85 log units), on the low side, outside the stated range (above it).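

In this assay, the step of a 5.3-fold higher number from compound 1 to compound 4 (0.72 log units; beyond the scatter) gives the first sign that this position is sensitive to the make-up of the chain, on a saturated chain carbon bound to an oxygen on a saturated carbon. With the heavy-atom count unchanged, 2,6-dimethylhepta-1,5-dien-1-yl in place of nonyl gives weaker inhibition, so the two chains are not interchangeable here. No measured property bears on this result, and the step stands unexplained.

This single pair leaves open whether the double bonds or the dimethyl substitution account for the step, and steps involving compound 2 and compound 3 cannot be read. From the compounds shown here alone, how a longer chain such as dodecyl, or a chain ending in an amine or a carboxylic acid, would compare with compound 1 also remains open.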